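The compounds below may be only part of what the source reports. "The series", "measured", "known", "first", "only" and "open" are said of these compounds alone.

Compound 1, `O=C(Nc1ccccc1)c1c(NO)cc(-c2ccccc2)oc1=O`, gives 11600 nM in an ADME assay on Huh-7 cells (Homo sapiens) for cytotoxicity, read by a luciferase reporter and WST assay, with a stated time of 3 days; a higher number here means that more compound is tolerated, a lower number that less compound is tolerated. Compound 2, `O=C(Nc1ccccc1)c1c(NO)cc(-c2ccc(Cl)cc2)oc1=O`, gives 11000 nM. Compound 3, `COc1ccc(-c2cc(NO)c(C(=O)Nc3ccccc3)c(=O)o2)cc1`, gives 16200 nM.

Compound 3 has the highest of the three numbers in this assay, but its margins are small: the step of a 1.4-fold higher number from compound 1 to compound 3 (0.15 log units; within the scatter) and the step of a 1.5-fold higher number from compound 2 to compound 3 (0.17 log units; within the scatter) both lie within the scatter, as does the step of a 1.1-fold lower number from compound 1 to compound 2 (0.02 log units; within the scatter). The three measured compounds therefore do not separate from one another in this assay.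

Compound 4, `COC(=O)CNC(=O)c1c(NO)cc(-c2ccc(OC)cc2)oc1=O`, is reached from compound 3 by the change ((methoxycarbonyl)methyl in place of phenyl on an amide-type nitrogen). For the measured compounds named here, none of the measured steps touches this part of the molecule; all three change only the aryl ring attached to the shared core, and all three stay within the scatter. There is thus no measured step that bears directly on the change to compound 4, and the measured steps give no reason to expect a move beyond the scatter in this assay.

Compound 4 is therefore expected to give about 17000 nM, within a range of 8000 nM to 36000 nM, which corresponds to an expected step of a 1.0-fold higher number from compound 3 to compound 4 (0.02 log units; within the scatter).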

Compound 4, half-maximal cytotoxic concentration: > 20000 nM
Compound 4: no number, only a limit (the forecaster's own chance of this, stated with the estimate: 15%); middle value at least 1.1-fold (0.07 log units) away from the limit.
By their numbers in this assay, from the lowest: compounds 2, 1 and 3 (each within the scatter of the next). At a limit, above all of these: compound 4.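

In this assay compound 4 gives > 20000 nM, which is a limit of the assay and not a number. The earlier steps shown here changed only the aryl ring on the shared core, whereas this one reaches the amide-type nitrogen, and (methoxycarbonyl)methyl in place of phenyl there gives an at least 1.2-fold higher number from compound 3 to compound 4 (0.09 log units; that floor lies within the scatter). The phenyl ring on this nitrogen can therefore be exchanged for an open chain with no lowering of the number, although the floor of the step does not separate the two compounds.

On these data alone, it remains open whether a carboxylic acid, a primary amide or a plain ethyl chain on this nitrogen would read the same way. Also open, as far as these compounds go, is how far the true value of compound 4 lies past its limit.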